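Phenyl to Cyclopropyl on a Shared Core

The source may hold more compounds than are shown below. What is called first, only, known or untested is meant among the compounds shown, and "the series" means these compounds.

Compound 1 `CCCCc1cc2nn(-c3ccccc3)cc2cn1`: in a functional assay on MCF7 cells (Homo sapiens) for inhibition, read by fluorescence, with a stated time of 72 h (on this read-out lower numbers stand for stronger inhibition of growth and higher numbers for weaker inhibition of growth), compound 1 gives 13300 nM.
Compound 2 `c1ccc(-c2cc3nn(-c4ccccc4)cc3cn2)cc1`: in this assay compound 2 gives 4800 nM.

Compound 2 holds the lower of the two numbers, the step of a 2.8-fold lower number from compound 1 to compound 2 (0.44 log units; beyond the scatter) being modest but beyond the scatter. Compound 3 `c1ccc(-n2cc3cnc(C4CC4)cc3n2)cc1` differs from compound 2 by cyclopropyl in place of phenyl on an aromatic carbon. For the measured compounds named here, the only measured step bearing on this, a 2.8-fold lower number from compound 1 to compound 2 (0.44 log units; beyond the scatter), replaced an alkyl group with phenyl and lowered the number; compound 3 reverses that direction with a smaller alkyl group, so a modest rise in this assay is expected, a 1.9-fold higher number from compound 2 to compound 3 (0.27 log units; within the scatter). Compound 3 is therefore estimated at 9000 nM, between 3500 nM and 25000 nM.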

Compound 3, concentration for 50% growth inhibition: 69300 nM
Compound 3: middle estimate off by 7.7-fold (0.89 log units), on the low side, outside the stated range (above it).
By their numbers in this assay, from the lowest: compound 2; then compound 1; then compound 3.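

For the compounds shown here, replacing phenyl with cyclopropyl on this aromatic carbon gives the largest step so far in this assay (a 14-fold higher number from compound 2 to compound 3 (1.16 log units; beyond the scatter)), so this position responds strongly to the group placed there. The two alkyl groups also differ from each other (a 5.2-fold higher number from compound 1 to compound 3 (0.72 log units; beyond the scatter)), so phenyl's advantage over butyl did not mean that all alkyl groups would sit close together. Nothing measured here explains these differences. Going by these compounds, it remains open whether an amine, a methoxy group or a substituted phenyl at this position would give a number lower than that of compound 2.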